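Chloro for fluoro in compound 4

The source may hold more compounds than are shown below. What is called first, only, known or untested is meant among the compounds shown, and "the series" means these compounds.

Values measured in a functional assay on OVCAR-3 cells (Homo sapiens) for antiproliferative activity, read by spectrophotometry, with a stated time of 2 days (on this read-out lower numbers stand for stronger inhibition of growth and higher numbers for weaker inhibition of growth), are:
- Compound 1 `Cc1ccc(Nc2ncc(C(F)(F)F)c(N3Cc4cccc(N(C)S(C)(=O)=O)c4C3)n2)c(Cl)c1` gives > 30000 nM which is a limit.
- Compound 2 `Cc1cc(F)ccc1Nc1ncc(C(F)(F)F)c(N2Cc3cccc(N(C)S(C)(=O)=O)c3C2)n1` gives > 30000 nM which is a limit.
- Compound 3 `CN(c1cccc2c1CN(c1nc(Nc3cccc(Oc4ccccc4)c3)ncc1C(F)(F)F)C2)S(C)(=O)=O` gives 24900 nM which is a number.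

Compound 2 stands at the limit of > 30000 nM in this assay, at which 2 of the 3 values shown sit, and so has no number. Compound 4 `Cc1cc(Cl)ccc1Nc1ncc(C(F)(F)F)c(N2Cc3cccc(N(C)S(C)(=O)=O)c3C2)n1` carries chloro in place of fluoro on an aromatic carbon and nothing else changes. Going by the values given here, the one measured step on this substituent is a step that the two limits leave unreadable from compound 1 to compound 2 and it offers no size to carry over. Among the compounds with values here, compound 3 gives the only number with 24900 nM but no step ties it to compound 4. The expected step of a number no higher from compound 2 to compound 4 (the limit leaves the size open) is estimated to stay within the scatter with no direction favoured. Compound 4 is expected at 30000 nM with an estimated range of 15000 nM to 60000 nM and may well come out only as a limit.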

Compound 4, concentration for 50% growth inhibition: > 30000 nM
Compound 4 gave a limit, no number; the forecaster's own chance of this, stated with the estimate: 80%; the middle value lies on the limit itself.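

The steps among compound 1, compound 2 and compound 4 cannot be read, since all three values are limits: the limit of > 30000 nM in this assay, at which 3 of the 4 values shown sit.

The compounds shown leave open how large any step from fluoro to chloro would be in this assay.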